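A few compounds are considered here, and "the series" means these few. Any claim that something is new, unique, unknown or untested is made for them only; others in the source may bear on it.

In an ADME assay on BE(2)-C cells (Homo sapiens) for cytotoxicity, read by MTT assay, with a stated time of 20 h; on this read-out lower numbers stand for higher toxicity in this test and higher numbers for lower toxicity in this test:
Compound 1 `O=C(NCCn1ccnc1)C1CCN(C(=O)c2cc3ccccc3n2Cc2ccc(Cl)cc2)CC1`: 99600 nM
Compound 2 `CN(Cc1ccccc1)C(=O)C1CCN(C(=O)c2cc3ccccc3n2Cc2ccc(Cl)cc2)CC1`: 87000 nM
Compound 3 `CN(Cc1ccccc1)C(=O)C1CCN(C(=O)c2cc3ccccc3n2Cc2ccc(C#N)cc2)CC1`: > 100000 nM

The entry for compound 3, > 100000 nM, is a limit of the assay and not a number. Compound 3 thus stands at the limit of > 100000 nM in this assay, at which 1 of the 3 values shown sits.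

Compound 4 `CC(C)Cn1c(C(=O)N2CCC(C(=O)N(C)Cc3ccccc3)CC2)cc2ccccc21` differs from compound 3 as follows: isopropyl in place of 4-cyanophenyl on a saturated chain carbon bound to an aromatic nitrogen. In words, this is isopropyl in place of 4-cyanophenyl on a saturated chain carbon bound to an aromatic nitrogen.

Within the data shown here, two measured steps bear on this change, both within the scatter. The nearer is an at least 1.1-fold higher number from compound 2 to compound 3 (0.06 log units; that floor lies within the scatter), which altered only the aromatic group that now leaves. The other, a 1.1-fold lower number from compound 1 to compound 2 (0.06 log units; within the scatter), lies on a carbonyl carbon elsewhere in the molecule. Neither replaced the whole aromatic group, so the evidence is indirect, and no step beyond the scatter is expected in this assay, in either direction. The expected size of the change is an at least 1.1-fold lower number from compound 3 to compound 4 (0.04 log units; that floor lies within the scatter). For compound 4 the estimate is 90000 nM, with an expected range of 40000 nM to 150000 nM.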

Compound 4, half-maximal cytotoxic concentration: 58200 nM
Compound 4: the middle estimate sits 1.5-fold (0.19 log units) above what was measured, and the stated range covers the measured number.
By their numbers in this assay, from the lowest: compounds 4, 2 and 1 (each within the scatter of the next). At a limit, above all of these: compound 3.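

In this assay, replacing the whole aromatic group with isopropyl on a saturated chain carbon bound to an aromatic nitrogen gives an at least 1.7-fold lower number from compound 3 to compound 4 (0.23 log units; that floor lies within the scatter) and a 1.5-fold lower number from compound 2 to compound 4 (0.17 log units; within the scatter) in the comparison with the chloro compound. The earlier steps shown here changed only a substituent on that aromatic group or a group elsewhere in the molecule, whereas these show that even removing the ring from this place does not take the number beyond the scatter. Compound 3 stands at a limit of the assay, not at a number: the limit of > 100000 nM in this assay, at which 1 of the 4 values shown sits.

The compounds shown leave open whether an amine, a carboxylic acid or a longer chain in place of the isobutyl group would give a step beyond the scatter in this assay. They also leave open how far the number for compound 3 lies past its limit.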